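Trimming the aryl group: metabolic stability of compound 4

The source may report more compounds than this note shows. Statements on the series, on what has been measured and on what is new or still open speak of the compounds shown alone.

Compound 1 `Cc1cc(C)c(-c2nc(CN3CCC(C(=O)NCCCN4C[C@H](C)C[C@H](C)C4)CC3)c(C)o2)c(C)c1` was run in an ADME assay on microsomes from liver (Rattus norvegicus) for metabolic stability, read by LC-MS, using NADPH, at 37 degrees C; a higher number here means that the compound lasts longer, a lower number that the compound disappears faster. In this assay compound 1 gives > 0.5 h, which is a limit of the assay rather than a number (the limit of > 0.5 h in this assay, at which 1 of the 3 values shown sits). Compound 2 `CC[C@@H]1C[C@H](CC)CN(CCCNC(=O)C2CCN(Cc3nc(-c4ccccc4C)oc3C)CC2)C1` gives 0.0917 h in this assay. Compound 3 `CC[C@@H]1C[C@H](CC)CN(CCCNC(=O)C2CCN(Cc3nc(-c4c(F)cccc4F)oc3C)CC2)C1` gives 0.065 h. The step of a 1.4-fold lower number from compound 2 to compound 3 (0.15 log units; within the scatter) swaps only the aryl group on the shared core. Compound 4 `Cc1cccc(F)c1-c1nc(CN2CCC(C(=O)NCCCN3C[C@H](C)C[C@H](C)C3)CC2)c(C)o1` differs from compound 1 by 2-fluoro-6-methylphenyl in place of 2,4,6-trimethylphenyl on an aromatic carbon. Among the compounds with values here, the measured step from compound 2 to compound 3 is the only change at the same place, and it stayed within the scatter, so no step beyond the scatter is expected here either. Compound 4 is therefore estimated at 0.5 h, between 0.25 h and 1 h, meaning an expected step of a number no higher from compound 1 to compound 4 (the limit leaves the size open).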

Compound 4, half-life: 0.0733 h
Estimate against measurement, compound 4: 6.8-fold (0.83 log units) above, outside the stated range (below it).
By their numbers in this assay, from the lowest: compounds 3, 4 and 2 (each within the scatter of the next). At a limit, above all of these: compound 1.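

At this place on the shared core, the aryl group can matter in this assay: the change gives an at least 6.8-fold lower number from compound 1 to compound 4 (0.83 log units; beyond the scatter). The earlier aryl change, a 1.4-fold lower number from compound 2 to compound 3 (0.15 log units; within the scatter), therefore does not speak for every aryl change here. The full size of the new step stays unknown, because compound 1 carries a limit of the assay rather than a number: the limit of > 0.5 h in this assay, at which 1 of the 4 values shown sits.

The compounds shown leave open whether the fluorine or the lost methyl group accounts for the step. As far as these compounds go, how a 2,6-dimethylphenyl or a 2-chloro-6-methylphenyl group would fare here also remains open.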